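Working notes: from compound 3 to compound 4

The compounds below may be only part of what the source reports. "The series", "measured", "known", "first", "only" and "open" are said of these compounds alone.

Measured so far in a functional assay on the whole organism with Mus musculus as the target; a higher number here means that more compound is needed for the effect, a lower number that less compound is needed
- compound 1 `CN1C(=O)CCC1(O)c1ccc(C(F)(F)F)cc1` gives > 200 mg/kg (a limit)
- compound 2 `CCCN1C(=O)CCC1(O)c1cccc(C(F)(F)F)c1` gives 200 mg/kg
- compound 3 `CC(C)NC(=O)CCC(=O)c1cccc(C(F)(F)F)c1` gives > 200 mg/kg (a limit)

Compound 3 sits at the limit of > 200 mg/kg in this assay, at which 2 of the 3 values shown sit. It therefore offers a limit and not a number. Compound 4 `CN1CCN(C(=O)CCC(=O)c2cccc(C(F)(F)F)c2)CC1` carries 4-methylpiperazin-1-yl in place of isopropylamino on a carbonyl carbon. For the measured compounds named here, no measured pair shows this change. Going by the values given here, the only number in this assay is that of compound 2, at 200 mg/kg, and the expectation rests on it. The estimated step of a number no higher from compound 3 to compound 4 (the limit leaves the size open) is expected to stay within the scatter, in neither direction. For compound 4 the expected value is 200 mg/kg, with an estimated range from 90 mg/kg to 400 mg/kg.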

Compound 4, dose for half-maximal effect: > 50 mg/kg
Compound 4 ended at the assay's limit (the forecaster's own chance of this, stated with the estimate: 55%); the middle value does not contradict the limit.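

In this assay, compound 3 and compound 4 both stand as limits and not as numbers, so no step can be read between them. On these data alone, whether 4-methylpiperazin-1-yl in place of isopropylamino on a carbonyl carbon changes the dose needed stays open.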